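A few compounds are considered here, and "the series" means these few. Any claim that something is new, unique, unknown or untested is made for them only; others in the source may bear on it.

Measured so far:
compound 1 `Cc1nc(SCC(=O)Nc2nc(-c3ccc(Cl)cc3)cs2)n(Nc2ccccc2)c1C`: 49300 nM in a functional assay on SNB-75 cells (Homo sapiens) for antiproliferative activity, read by sulforhodamine B assay, with a stated time of 48 h; a lower number here means that less compound is tolerated, a higher number that more compound is tolerated
compound 2 `Cc1ccc(Nn2c(SCC(=O)Nc3nc(-c4ccccc4)cs3)nc(C)c2C)cc1`: > 100000 nM, a limit of the assay, not a number

For the measured compounds named here, compound 1 holds the only number in this assay. Compound 2 reaches only the limit of the limit of > 100000 nM in this assay, at which 1 of the 2 values shown sits, so nothing beyond that is known for it.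

Compound 3 `COc1ccc(Nn2c(SCC(=O)Nc3nc(-c4ccc(Cl)cc4)cs3)nc(C)c2C)cc1` is not yet measured. Against compound 1 the change is methoxy in place of hydrogen on an aromatic carbon, para to a large group.

Going by the values given here, no step between measured compounds is available to calibrate this change. Compound 1 already stands at a high concentration, and the expectation is a small step from compound 1 to compound 3 of a 1.4-fold higher number from compound 1 to compound 3 (0.15 log units; within the scatter), toward more compound being tolerated, within the scatter or barely beyond it. For compound 3 the estimate is 70000 nM, spanning 30000 nM to 160000 nM, with a real chance that only a limit is reported.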

Compound 3, concentration lethal to 50% of the cells: > 100000 nM
Compound 3: a limit, no number; the forecaster's own chance of this, stated with the estimate: 35%; middle value at least 1.4-fold (0.15 log units) from the limit.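

In this assay, methoxy in place of hydrogen on an aromatic carbon, para to a large group, gives an at least 2.0-fold higher number from compound 1 to compound 3 (0.30 log units; that floor lies within the scatter). Compound 3 gives > 100000 nM, a limit of the assay and not a number. Only a floor is therefore known for this change, and the series already crowds the top of the readable range: the limit of > 100000 nM in this assay, at which 2 of the 3 values shown sit.

As far as these compounds go, whether the change moves the true value beyond the scatter stays open. Also open, from the compounds shown here alone, is whether an amine or fluorine at the same position would give a readable number.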